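The source may report more compounds than this note shows. Statements on the series, on what has been measured and on what is new or still open speak of the compounds shown alone.

Measured so far:
Compound 1, `O=C(O)CCCc1ccc(NCc2cccc(Oc3ccccc3)c2)cc1`: 59%
Compound 2, `O=C(O)CSc1ccc(NCc2cccc(Oc3ccccc3)c2)cc1`: 84%

Both compounds share one core and differ only in the acid-bearing group on the aromatic carbon. In a functional assay on CHO cells for agonist activity at Free fatty acid receptor 1 (Homo sapiens), read by a luciferase reporter (a higher number here means a larger maximal response, a lower number a smaller maximal response), compound 1 gives 59%, and compound 2 gives 84%. Among the compounds with values here, the single step between them, a number 25 percentage points higher from compound 1 to compound 2 (beyond the scatter), shows that exchanging the acid-bearing group is enough to move the maximal response beyond the scatter. Within the data shown here, compound 2 thus stands highest of the two numbers, with compound 1 the only neighbour.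

Compound 3, `O=C(O)[C@@H]1C[C@H]1c1ccc(NCc2cccc(Oc3ccccc3)c2)cc1`, is not yet measured. Its change from compound 2 is 2-carboxycyclopropyl in place of (carboxymethyl)sulfanyl on an aromatic carbon, again an exchange of the acid-bearing group on the same aromatic carbon, para to a large group. Among the measured compounds shown here, the step from compound 1 to compound 2 bears on this, being of modest size, and it indicates that this position tolerates variation while remaining active; but with only one such step and no measured compound carrying a carboxylic acid on a three-membered ring, the direction cannot be read from the data. Compound 3 is therefore expected to fall near or somewhat below compound 2, with the estimate set at 72%, range 45% to 95%, corresponding to an expected step of a number 12 percentage points lower from compound 2 to compound 3 (beyond the scatter).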

Compound 3, largest response reached (reported as percent of maximum), in percent of the reference or control that the assay uses: 64%
The estimate for compound 3 lay 8 percentage points above the measured number; measured number inside the range.
By their numbers in this assay, from the lowest: compounds 1 and 3 (each within the scatter of the next); then compound 2.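

In this assay the 2-carboxycyclopropyl group in place of (carboxymethyl)sulfanyl gives a number 20 percentage points lower from compound 2 to compound 3 (beyond the scatter), so this aromatic carbon does not keep the higher response across every exchange of the acid-bearing group. Against the 3-carboxypropyl group, the same ring-bearing group gives a number 5 percentage points higher from compound 1 to compound 3 (within the scatter), which leaves these two groups indistinguishable in this read-out despite the three-membered ring and the defined stereocentres. Among the three groups shown, only (carboxymethyl)sulfanyl stands apart from the other two, so the gain seen with compound 2 does not extend to compound 3 and remains tied, within this small set, to that one group.

No supporting measurement on hand bears on what lies behind these differences. Still open, going by these compounds, is whether the higher response of compound 2 follows the sulfur or the short chain, a question that an oxygen in place of the sulfur or a longer sulfanyl chain ending in a carboxylic acid would address, while the other stereoisomers of 2-carboxycyclopropyl and a tetrazole in place of the carboxylic acid are also open.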